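A few compounds are considered here, and "the series" means these few. Any claim that something is new, unique, unknown or untested is made for them only; others in the source may bear on it.

Working notes on the series, read in a functional assay on the whole organism (strain Sprague-Dawley) for inhibition, with Rattus norvegicus as the target; on this read-out higher numbers stand for an effect only at larger amounts of compound and lower numbers for an effect already at smaller amounts. Compound 1 `COc1ccc2ncc(-c3nn[nH]n3)cc2c1` gives 10 mg/kg; compound 2 `CCCCc1ccc2ncc(-c3nn[nH]n3)cc2c1` gives 5 mg/kg; compound 3 `c1ccc2ncc(-c3nn[nH]n3)cc2c1` gives 10 mg/kg. Compound 1 stands level with compound 3 at the digits shown, the two together the highest numbers of the three; the step of no change at the digits printed from compound 1 to compound 3 (within the scatter) and the step of a 2.0-fold lower number from compound 1 to compound 2 (0.30 log units; within the scatter) both stay within the scatter, as does a 2.0-fold higher number from compound 2 to compound 3 (0.30 log units; within the scatter). Compound 4 `COc1ccc2ncc(C(=O)O)cc2c1` differs from compound 1 in one place: carboxy in place of 2H-tetrazol-5-yl on an aromatic carbon. For the measured compounds named here, none of the measured steps touches this group; all three concern only the exchange of methoxy, butyl and hydrogen, so no direction can be read from them for the new group. The expectation for compound 4 is therefore a step of a 1.5-fold higher number from compound 1 to compound 4 (0.18 log units; within the scatter) that stays within the scatter, with a wide range allowed. Compound 4 is expected near 15 mg/kg, between 5 mg/kg and 50 mg/kg.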

Compound 4, minimum effective dose: > 5 mg/kg
Compound 4: a limit, no number; the forecaster's own chance of this, stated with the estimate: 15%; the middle value lies beyond the limit too.
By their numbers in this assay, from the lowest: compounds 2, 1 and 3 (each within the scatter of the next).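

In this assay compound 4 gives > 5 mg/kg, a limit and not a number, so no step can be read between compound 1 and compound 4. As far as these compounds go, whether carboxy in place of 2H-tetrazol-5-yl changes the minimum effective dose, and in which direction, stays open.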